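The source may report more compounds than this note shows. Statements on the series, on what has been measured and on what is new or still open speak of the compounds shown alone.

Compound 1 `Cn1c(-c2ccc(NC(=O)CN3CCCCC3)cc2)nc2cc(C(F)(F)F)ccc21`: 100000 nM
Compound 2 `O=C(CN1CCCC1)Nc1ccc(-c2nc3cc(C(F)(F)F)ccc3[nH]2)cc1`: 15000 nM
Compound 3 `O=C(CN1CCCC1)Nc1ccc(-c2nc3ccccc3[nH]2)cc1`: 70000 nM

All three were measured in an ADME assay on MDBK cells (Bos taurus) for cytotoxicity, read by MTT assay, with a stated time of 96 h; a higher number here means that more compound is tolerated, a lower number that less compound is tolerated. Compound 2 gives the lowest of the three numbers, meaning the least compound is tolerated; compound 3 stands nearest to it and compound 1 furthest. Compound 4 `O=[N+]([O-])c1ccc(-c2nc3cc(C(F)(F)F)ccc3[nH]2)cc1` differs from compound 2 by nitro in place of (((pyrrolidin-1-yl)methyl)carbonyl)amino on an aromatic carbon. Within the data shown here, the one measured step, a 4.7-fold higher number from compound 2 to compound 3 (0.67 log units; beyond the scatter), concerns the trifluoromethyl, which compound 4 keeps, so it does not speak to exchanging the group on the aromatic carbon para to a large group. Among the measured compounds shown here, no measured step bears on this change, and its direction is open. Compound 4 is therefore expected to stay near compound 2, an estimated step of a 1.5-fold lower number from compound 2 to compound 4 (0.18 log units; within the scatter), with a wide range. For compound 4 the expected value in this assay is 10000 nM, between 2000 nM and 60000 nM.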

Compound 4, half-maximal cytotoxic concentration: 6000 nM
Compound 4: the middle estimate sits 1.7-fold (0.22 log units) above what was measured, within the range that was stated.
By their numbers in this assay, from the lowest: compound 4; then compound 2; then compounds 3 and 1 (each within the scatter of the next).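

In this assay, this position proves sensitive to what it carries: a 2.5-fold lower number from compound 2 to compound 4 (0.40 log units; beyond the scatter) comes with nitro in place of (((pyrrolidin-1-yl)methyl)carbonyl)amino on the aromatic carbon para to a large group. Removing that ring-bearing chain therefore does not raise the tolerated amount here. Nothing measured explains the shift.

The compounds shown do not separate the effect of losing the chain from that of gaining nitro. From the compounds shown here alone, a simple amine at this position would help to test this, and the step's dependence on the trifluoromethyl also remains open.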